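Removing the Chloromethyl Group from a Sulfonamide Urea

The source may report more compounds than this note shows. Statements on the series, on what has been measured and on what is new or still open speak of the compounds shown alone.

compound 1 `Cc1ccccc1OS(=O)(=O)c1ccc(NC(=O)NCCCCl)cc1`: 25000 nM
compound 2 `Cc1ccccc1NS(=O)(=O)c1ccc(NC(=O)NCCCCl)cc1`: > 200000 nM

Of the compounds shown here, two have been measured in a functional assay on M21 cells (Homo sapiens) for cytotoxicity, read by sulforhodamine B assay, with a stated time of 48 h; on this read-out lower numbers stand for stronger inhibition and higher numbers for weaker inhibition. Compound 1 gives 25000 nM. Compound 2 gives no number, only a limit, > 200000 nM, as noted under (the limit of > 200000 nM in this assay, at which 1 of the 2 values shown sits). Within the data shown here, the one measured step, an at least 8.0-fold higher number from compound 1 to compound 2 (0.90 log units; beyond the scatter), concerns the sulfonyl sulfur and not the urea chain.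

Compound 3 `CCNC(=O)Nc1ccc(S(=O)(=O)Nc2ccccc2C)cc1` differs from compound 2 by hydrogen in place of chloromethyl on a saturated chain carbon, two bonds along the chain from an amide-type nitrogen. No measured step touches this part of the structure, so the size of the change from compound 2 to compound 3 cannot be read from the numbers shown. Compound 2 sits at the limit > 200000 nM. Compound 3 is therefore expected to remain at that limit, with an expected step that the limit leaves unreadable from compound 2 to compound 3. Compound 3 is estimated at 300000 nM, within a range from 150000 nM to 1000000 nM.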

Compound 3, half-maximal inhibitory concentration: > 200000 nM
Compound 3: only a limit was reported (the forecaster's own chance of this, stated with the estimate: 85%); the middle value is on the limit's open side.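

Compound 3 gives only a limit, > 200000 nM, in this assay, and compound 2 likewise gives only a limit, so no step can be read between the two: the limit of > 200000 nM in this assay, at which 2 of the 3 values shown sit.

The compounds shown leave open how far hydrogen in place of chloromethyl moves the number in this assay.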